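Nitro for hydroxy on the cinnamoyl aryl: cytotoxicity outlook

This account rests on a few compounds, and the source may have more. Where it says the series, first, only, none or still open, it means among the compounds named here.

Compound 3 `O=C(/C=C\c1ccc(O)cc1)N1N=C(c2ccncc2)OC1c1c[nH]c2ccccc12` shares its core with compound 1 `O=C(/C=C\c1ccccc1)N1N=C(c2ccncc2)OC1c1c[nH]c2ccccc12` and differs from it by a hydroxy in place of hydrogen on an aromatic carbon. In an ADME assay on A549 cells (Homo sapiens) for cytotoxicity, read by MTT assay, with a stated time of 48 h (on this read-out higher numbers stand for weaker inhibition of growth and lower numbers for stronger inhibition of growth), compound 3 returns only a limit, > 30 ug/mL. Compound 1 likewise returns only a limit in this assay, > 30 ug/mL. Compound 2 `O=C(/C=C\c1cccc(O)c1)N1N=C(c2ccncc2)OC1c1c[nH]c2ccccc12` also gives no number but a limit in this assay, > 30 ug/mL. As a result the steps among these three, a step that the two limits leave unreadable from compound 1 to compound 2, a step that the two limits leave unreadable from compound 1 to compound 3 and a step that the two limits leave unreadable from compound 2 to compound 3, carry no readable size, because every value rests at the limit of > 30 ug/mL in this assay, at which 3 of the 3 values shown sit.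

Compound 4 `O=C(/C=C\c1cccc([N+](=O)[O-])c1)N1N=C(c2ccncc2)OC1c1c[nH]c2ccccc12` differs from compound 3 by 3-nitrophenyl in place of 4-hydroxyphenyl on a double-bonded chain carbon bound to a double-bonded chain carbon. For the measured compounds named here, no measured step bears on this exchange with a number, and the hydroxy series itself shows no growth inhibition within the tested range. The expected step from compound 3 to compound 4 in this assay, a step that the limit leaves unreadable from compound 3 to compound 4, is therefore set at none beyond the scatter, with the most likely outcome a further limit rather than a number. Compound 4 is expected to give about 40 ug/mL in this assay, with a range from 18 ug/mL to 90 ug/mL.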

Compound 4, concentration for 50% growth inhibition: > 30 ug/mL
Compound 4: no number, only a limit (the forecaster's own chance of this, stated with the estimate: 75%); the middle value does not contradict the limit.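

Compound 4 returns only a limit in this assay, and no new step can be read from it to compound 1, compound 2 or compound 3: the limit of > 30 ug/mL in this assay, at which 4 of the 4 values shown sit.

The compounds shown leave open whether 3-nitrophenyl, 4-hydroxyphenyl and the aryl groups of compound 1 and compound 2 differ at all in growth inhibition on the shared core.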